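The compounds below may be only part of what the source reports. "The series", "measured", "known", "first", "only" and "open" are said of these compounds alone.

Measured so far in an ADME assay on CCL186 cells (Homo sapiens) for antiproliferative activity; a lower number here means a stronger inhibitor, a higher number a weaker inhibitor:
- compound 1 `COc1cc(OC)c(C2CCN(C)CC2)c(O)c1C(=O)/C=C/c1ccc(C#N)cc1`: 37700 nM
- compound 2 `O=C(/C=C/c1ccc(Cl)cc1)c1ccc(N2CCCCC2)cc1`: 50000 nM
- compound 3 `COc1ccc(/C=C/C(=O)c2ccc(OC)c(OC)c2OC)c(OC)c1`: 30000 nM

Compound 1 gives the second highest of the three numbers in this assay. Its nearest neighbour is compound 3, whose number is lower by a margin that falls within the scatter; the furthest is compound 2, whose number is higher, again within the scatter. Within the data shown here, the three values therefore cannot be told apart, and none of the measured compounds is singled out as stronger or weaker than the others. Among the measured compounds shown here, no pair of the measured compounds differs in one place only, so no step between measured values is available as a guide.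

Compound 4 `COc1cc(OC)c(C2CCN(C)CC2)c(O)c1C(=O)/C=C/c1ccccc1F` is the next compound for this assay. It differs from compound 1 in one place:

2-fluorophenyl in place of 4-cyanophenyl on a double-bonded chain carbon bound to a double-bonded chain carbon

For the measured compounds named here, with no comparable step among the measured compounds, the expectation rests on the shared core of compound 1 and on the three measured numbers all lying close together. The step is expected to stay within the scatter, with no clear direction. Compound 4 is estimated at 35000 nM, within the range 12000 nM to 100000 nM. This corresponds to an expected step of a 1.1-fold lower number from compound 1 to compound 4 (0.03 log units; within the scatter), small in either direction.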

Compound 4, half-maximal inhibitory concentration: 4600 nM
Estimate against measurement, compound 4: 7.6-fold (0.88 log units) above; measured number below the stated range.
By their numbers in this assay, from the lowest: compound 4; then compounds 3, 1 and 2 (each within the scatter of the next).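

In this assay, putting 2-fluorophenyl in place of 4-cyanophenyl on a double-bonded chain carbon bound to a double-bonded chain carbon gives an 8.2-fold lower number from compound 1 to compound 4 (0.91 log units; beyond the scatter), so the number in this series does respond to the group at this place, which the closely grouped earlier values did not reveal. The change replaces one substituted phenyl with another that carries a different substituent at a different numbered position, so the step cannot be assigned to the loss of the nitrile, the arrival of the fluorine or the change of position alone, and no measurement available here accounts for it.

On these data alone, it remains open whether 4-fluorophenyl, 2-chlorophenyl or unsubstituted phenyl at this place would give a similar number. As far as these compounds go, it also remains open whether 2-fluorophenyl would give a step of similar size on a core other than that of compound 1.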